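The source may report more compounds than this note shows. Statements on the series, on what has been measured and on what is new or still open speak of the compounds shown alone.

Measured so far:
- compound 1, `CCS(=O)(=O)Nc1cc(C2CCCCC2)cc2c1CCCC2c1c[nH]cn1` — 447 nM
- compound 2, `CS(=O)(=O)Nc1cccc2c1CCCCC2c1c[nH]cn1` — 2510 nM
- compound 3, `CCS(=O)(=O)Nc1cccc(C2CCNC2)c1` — 1000 nM

In an assay on isolated protein for binding affinity to Alpha-1D adrenergic receptor (Rattus norvegicus), read by radioligand binding (on this read-out lower numbers stand for stronger inhibition and higher numbers for weaker inhibition), compound 3 stands second highest of the three numbers. Compound 1 gives a lower number and compound 2 a higher one, and both differences lie beyond the usual scatter.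

Compound 4, `CCS(=O)(=O)Nc1cccc(NC2=NCCN2)c1`, has not yet been measured. It differs from compound 3 in a single place: a group of 6 heavy atoms (3 carbon, 3 nitrogen; one five-membered non-aromatic ring with 2 hetero atoms) in place of a group of 5 heavy atoms (4 carbon, 1 nitrogen; one five-membered non-aromatic ring with 1 hetero atom), on an aromatic carbon. The change sits on an aromatic carbon of a six-membered aromatic ring of carbon only, meta to a group of 6 heavy atoms.

Within the data shown here, no step between measured compounds gives a guide for this exchange. The expected step of a 1.4-fold lower number from compound 3 to compound 4 (0.15 log units; within the scatter) is small, with no clear direction beyond the scatter. Compound 4 is therefore estimated at 700 nM, within 150 nM to 3000 nM.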

Compound 4, inhibition constant: 355 nM
For compound 4 the middle estimate is 2.0-fold (0.29 log units) above the measured one; the range from low to high includes it.
By their numbers in this assay, from the lowest: compounds 4 and 1 (each within the scatter of the next); then compound 3; then compound 2.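

On the aromatic carbon meta to a group of 6 heavy atoms, replacing pyrrolidin-3-yl with the five-membered non-aromatic ring with 2 hetero atoms gives a 2.8-fold lower number from compound 3 to compound 4 (0.45 log units; beyond the scatter) in this assay. Among these compounds, this is the only single-place step, and it shows that the affinity reading responds to the group at this position. No measurement shown explains the step. On these data alone, whether a simple amine or a carboxylic acid at this place would move the number further remains open, as does whether the step would hold on the core of compound 1.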